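A few compounds are considered here, and "the series" means these few. Any claim that something is new, unique, unknown or untested is made for them only; others in the source may bear on it.

Working notes on the series. Compound 2 `Cn1ccnc1[C@@H](CC(=O)O)c1ccc(OCc2cccc(-c3ccccc3S(C)(=O)=O)c2)cc1` carries a 2-(methylsulfonyl)phenyl group on the shared core; in an assay on CHO cells for agonist activity at Free fatty acid receptor 1 (Homo sapiens), read by luminescence, with a stated time of 20 s, in the presence of a further agent that is not named here (on this read-out higher numbers stand for an effect only at larger amounts of compound and lower numbers for an effect already at smaller amounts), compound 2 stands at "not determined" (no result reported), so no number fixes its place on this read-out. Compound 3 `COc1ccccc1-c1cccc(COc2ccc([C@H](CC(=O)O)c3nccn3C)cc2)c1` likewise stands at "not determined" (no result reported) in this assay. For the measured compounds named here, the only number in the set comes from compound 1 `Cc1ccccc1-c1cccc(COc2ccc([C@H](CC(=O)O)c3nccn3C)cc2)c1`, which in this assay gives 89000 nM; the set therefore holds one measured point and two blanks, and no step between measured compounds can be drawn.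

Compound 4 `Cc1ccc(F)cc1-c1cccc(COc2ccc([C@H](CC(=O)O)c3nccn3C)cc2)c1` is the next entry. Relative to compound 2 the change is 5-fluoro-2-methylphenyl in place of 2-(methylsulfonyl)phenyl on an aromatic carbon. With compound 2 unnumbered, the direction of the step in this assay cannot be read from data; the expectation is for no change beyond the scatter of this assay, with compound 1 as the only anchor. On that anchor compound 4 is estimated in this assay at 60000 nM, expected to fall between 20000 nM and 200000 nM.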

Compound 4, half-maximal effective concentration: 42000 nM
Estimate against measurement, compound 4: 1.4-fold (0.15 log units) above; measured number inside the range.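

Fluoro in place of hydrogen on an aromatic carbon gives, in this assay, a 2.1-fold lower number from compound 1 to compound 4 (0.33 log units; beyond the scatter), the first readable step in the set, showing that the read-out responds to a change on this ring. The steps involving compound 2 and compound 3 cannot be read, since neither compound has a number on this read-out. Nothing measured here gives a reason for the step.

On these data alone, it remains open whether chloro, trifluoromethyl or an amine in place of the fluoro would move the number further, or back toward that of compound 1. Also open, as far as these compounds go, is whether fluoro would give a step of similar size on another aromatic carbon of the ring or with the methyl group replaced by an ethyl group.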